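Ethylamino Step on a Vinyl Core: Expected Potency Loss

This account rests on a few compounds, and the source may have more. Where it says the series, first, only, none or still open, it means among the compounds named here.

Compound 1 `CNCC(=O)Nc1cc(OC)ccc1C(=O)c1cc(OC)c(OC)c(OC)c1`: 690 nM in a functional assay on HeLa cells (Homo sapiens) for antiproliferative activity, read by MTT assay, with a stated time of 48 h; a higher number here means a weaker inhibitor, a lower number a stronger inhibitor
Compound 2 `CCNCC(=O)Nc1cc(OC)ccc1C(=O)c1cc(OC)c(OC)c(OC)c1`: 2100 nM
Compound 3 `C=C(c1cc(OC)c(OC)c(OC)c1)c1ccc(OC)cc1NC(=O)CNC`: 140 nM

Compound 2 differs from compound 1 only by methyl in place of hydrogen on a saturated chain carbon bound to an amine nitrogen, and in this assay that change gave a 3.0-fold higher number from compound 1 to compound 2 (0.48 log units; beyond the scatter). Compound 3 carries a different core; the difference between the two cores is not broken down here. Of the three measured numbers, compound 3 shows the lowest, with compound 1 nearest to it and compound 2 furthest, both gaps beyond the scatter.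

Compound 4 `C=C(c1cc(OC)c(OC)c(OC)c1)c1ccc(OC)cc1NC(=O)CNCC` is not yet measured. It differs from compound 3 by methyl in place of hydrogen on a saturated chain carbon bound to an amine nitrogen, the same change, in the same place, that separates compound 1 from compound 2. Among the compounds with values here, only one earlier pair shows this change, on the other core, so how far it carries over is not known.

Compound 4 is estimated to give 420 nM in this assay, with a range from 200 nM to 900 nM expected. The expected step is a 3.0-fold higher number from compound 3 to compound 4 (0.48 log units; beyond the scatter), resting on the earlier step because that same change gave a 3.0-fold higher number from compound 1 to compound 2 (0.48 log units; beyond the scatter).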

Compound 4, half-maximal inhibitory concentration: 430 nM
Compound 4: the middle estimate sits 1.0-fold (0.01 log units) below what was measured, and the stated range covers the measured number.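

In this assay, the change from methylamino to ethylamino gave a 3.1-fold higher number from compound 3 to compound 4 (0.49 log units; beyond the scatter), so the step seen on the core of compound 1 appeared again on the core of compound 3. Set side by side, the two steps agree: the same change on two cores in this assay, a 3.0-fold higher number (0.48 log units; beyond the scatter) from compound 1 to compound 2 and a 3.1-fold higher number (0.49 log units; beyond the scatter) from compound 3 to compound 4, 1.0-fold (0.00 log units) apart, within the scatter of two such steps

This shows that, for these two cores, the change carried over with its size intact, even though the two cores start from different numbers. Within the data shown here, it rests on only two pairs, however, and it does not show that the same step would hold on any further core, nor does it explain what lies behind the step.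

The compounds shown leave open whether a longer chain, as in propylamino, or a branched one, as in isopropylamino, would continue the same trend on either core. They also leave open how a primary amine or a tertiary amine such as dimethylamino would compare with methylamino on these two cores.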